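Moving a hydroxyl group on a naphthyloxyacetyl hydrazone

A few compounds are considered here, and "the series" means these few. Any claim that something is new, unique, unknown or untested is made for them only; others in the source may bear on it.

Measured compounds:
compound 1, `O=C(COc1cccc2ccccc12)N/N=C/c1ccc(O)cc1`, with 3.73
compound 2, `C/C(=N\NC(=O)COc1cccc2ccccc12)c1ccc(O)cc1`, with 4.44

Both compounds were tested in a physicochemical assay for lipophilicity, measured as octanol-water partition; a higher number here means a more lipophilic compound, a lower number a more polar compound. Going by the values given here, compound 1 has the lower of the two numbers, and compound 2 sits a good way above it, beyond the usual scatter; since no step between them is worked out here, the two values speak only for themselves.

The piece now follows the step from compound 1 to compound 3, `O=C(COc1cccc2ccccc12)N/N=C/c1ccccc1O`, which has not yet been measured in this assay. The two have the same atoms, joined differently: 2-hydroxyphenyl in place of 4-hydroxyphenyl on a carbon with a double bond to nitrogen. Among the compounds with values here, no measured step of this kind is available, so the expectation rests on the structures alone. A small upward step is expected, at about the edge of the scatter, as a number 0.32 log units higher from compound 1 to compound 3 (beyond the scatter). Compound 3 is therefore estimated at 4.05, within a range from 3.6 to 4.5.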

Compound 3, partition coefficient: 3.73
For compound 3 the middle estimate is 0.32 log units above the measured one; the range from low to high includes it.
By their numbers in this assay, from the lowest: compounds 1 and 3 (each within the scatter of the next); then compound 2.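

In this assay, putting 2-hydroxyphenyl in place of 4-hydroxyphenyl on a carbon with a double bond to nitrogen gives no change at the digits printed from compound 1 to compound 3 (within the scatter). Going by these compounds alone, this is the first step that can be read at this place, and it shows that, for this pair, rearranging the same atoms leaves the partition reading within the scatter. Nothing at hand bears on why the two readings agree.

On these data alone, one pair is a narrow basis, so it remains open whether the same holds for other groups at this place, such as 3-hydroxyphenyl, a methoxyphenyl or an aminophenyl. As far as these compounds go, it is also open whether 2-hydroxyphenyl in place of 4-hydroxyphenyl would behave the same way on the methyl-bearing carbon of compound 2.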